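Benzyl-substituted nucleosides: from dimethoxy to difluoro

The source may hold more compounds than are shown below. What is called first, only, known or untested is meant among the compounds shown, and "the series" means these compounds.

- compound 1 `Cc1cccc(CNc2ncnc3c2ncn3[C@@H]2O[C@H](CO)[C@@H](O)[C@H]2O)c1` | > 166000 nM (a limit)
- compound 2 `COc1cccc(CNc2ncnc3c2ncn3[C@@H]2O[C@H](CO)[C@@H](O)[C@H]2O)c1OC` | "not determined" (no result reported) (no result)

In a functional assay on G-361 cells (Homo sapiens) for antiproliferative activity, with a stated time of 72 h (a higher number here means a weaker inhibitor, a lower number a stronger inhibitor), compound 2 stands as "not determined" (no result reported) and has no number of its own. For the measured compounds named here, the only other entry gives compound 1 as > 166000 nM and that is a limit, not a number. Compound 3 `OC[C@H]1O[C@@H](n2cnc3c(NCc4ccc(F)cc4F)ncnc32)[C@H](O)[C@@H]1O` is the next to be measured in this assay with the same shared core. The structural change is 2,4-difluorophenyl in place of 2,3-dimethoxyphenyl on a saturated chain carbon bound to a nitrogen on an aromatic ring and reads as 2,4-difluorophenyl in place of 2,3-dimethoxyphenyl on a saturated chain carbon bound to a nitrogen on an aromatic ring. Going by the values given here, no measured step anchors this change. A modest shift toward stronger inhibition is expected relative to the limit of compound 1 at > 166000 nM in this series, with a limit result remaining quite possible. Compound 3 is estimated at 60000 nM with an expected range from 8000 nM to 166000 nM in this assay.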

Compound 3, half-maximal inhibitory concentration: > 166000 nM
Compound 3 ended at the assay's limit (the forecaster's own chance of this, stated with the estimate: 45%); at least 2.7-fold (0.44 log units) between middle value and limit.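

In this assay, no step can be read from compound 1 to compound 3, as both results are limits and not numbers: the limit of > 166000 nM in this assay, at which 2 of the 3 values shown sit.

Left open is whether 2,4-difluorophenyl and 3-methylphenyl differ at all in antiproliferative activity on the shared core, and whether any group at this place gives a readable value.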